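Trifluoromethyl for Fluoro: Expected Effect on Vero Cytotoxicity

The compounds below may be only part of what the source reports. "The series", "measured", "known", "first", "only" and "open" are said of these compounds alone.

Compound 3 `O=C(Nc1nc(-c2cccc(F)c2)cs1)c1ccc([N+](=O)[O-])o1` gives 51600 nM in an ADME assay on Vero cells (Chlorocebus sabaeus) for cytotoxicity, read by MTT assay, with a stated time of 72 h (on this read-out lower numbers stand for stronger inhibition and higher numbers for weaker inhibition), the second highest of the three numbers measured. Compound 1 `COc1ccc(-c2csc(NC(=O)c3ccc([N+](=O)[O-])o3)n2)cc1` gives 63000 nM and compound 2 `COc1ccccc1-c1csc(NC(=O)c2ccc([N+](=O)[O-])o2)n1` gives 42000 nM. All three steps among these compounds stay within the scatter: a 1.5-fold lower number from compound 1 to compound 2 (0.18 log units; within the scatter), a 1.2-fold lower number from compound 1 to compound 3 (0.09 log units; within the scatter) and a 1.2-fold higher number from compound 2 to compound 3 (0.09 log units; within the scatter). Compound 4 `O=C(Nc1nc(-c2cccc(C(F)(F)F)c2)cs1)c1ccc([N+](=O)[O-])o1` differs from compound 3 by trifluoromethyl in place of fluoro on an aromatic carbon. Among the compounds with values here, none of the measured steps exchanges a fluoro for a trifluoromethyl, so they bear on this change only loosely, showing merely that exchanges of the attached group on the shared core have so far moved this assay little. The expected step of a 1.1-fold lower number from compound 3 to compound 4 (0.06 log units; within the scatter) is therefore none beyond the scatter. Compound 4 is estimated at 45000 nM, with a range from 18000 nM to 110000 nM.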

Compound 4, half-maximal inhibitory concentration: 23900 nM
For compound 4 the middle estimate is 1.9-fold (0.27 log units) above the measured one, and the stated range covers the measured number.
By their numbers in this assay, from the lowest: compounds 4, 2, 3 and 1 (each within the scatter of the next, the first and the last beyond it).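

In this assay trifluoromethyl in place of fluoro gives a 2.2-fold lower number from compound 3 to compound 4 (0.33 log units; beyond the scatter) and, unlike the three earlier steps, lies beyond the scatter, though only modestly. Within the data shown here, a single exchange at this place, meta to a large group, can therefore shift the number, which the earlier compounds did not show. Nothing at hand explains this step. The compounds shown leave open whether a methyl group, a nitrile or an amine at the same place would shift the number as well. Also open, on these data alone, is whether trifluoromethyl elsewhere on this ring would give a similar step.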